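Dichlorophenyl sulfone with fluoro core: expected displacement

The source may report more compounds than this note shows. Statements on the series, on what has been measured and on what is new or still open speak of the compounds shown alone.

Measured so far in an assay on isolated protein for displacement of a labelled ligand from metabotropic glutamate receptor 5 (Homo sapiens), with a stated time of 60 min, tested at 1 uM; a lower number here means less inhibition, a higher number more inhibition at the concentration tested (going by the name of the read-out):
compound 1 `CC1CCN(c2c(S(=O)(=O)c3ccccc3)cnc3ccc(F)cc23)CC1` gives 40%
compound 2 `CC1CCN(c2c(S(=O)(=O)c3ccc(F)cc3)cnc3ccc(F)cc23)CC1` gives 87%
compound 3 `Cc1ccc2ncc(S(=O)(=O)c3cc(Cl)cc(Cl)c3)c(N3CCC(C)CC3)c2c1` gives 75%

Compound 3 stands second highest of the three numbers in this assay; compound 2 lies above it and compound 1 below it, both gaps beyond the scatter. Compound 4 `CC1CCN(c2c(S(=O)(=O)c3cc(Cl)cc(Cl)c3)cnc3ccc(F)cc23)CC1` is not yet measured. It differs from compound 3 in one place: fluoro in place of methyl on an aromatic carbon.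

Among the compounds with values here, the one measured step, a number 47 percentage points higher from compound 1 to compound 2 (beyond the scatter), exchanges hydrogen for fluoro, and the fluoro that enters there sits elsewhere in the molecule; no measured step exchanges methyl for fluoro on the core. That step therefore bears on the present change only loosely. Compound 4 carries the same fluoro core as compounds 1 and 2 and the same sulfone substituent as compound 3, and compound 3 already gives 75%. A step of modest size, near the scatter, is expected.

Compound 4 is estimated at 78%, in the range 60% to 92%, which means an expected step of a number 3 percentage points higher from compound 3 to compound 4 (within the scatter).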

Compound 4, a percentage reported as inhibition, at one concentration (the size of the read-out at that concentration, not a potency): 69%
The estimate for compound 4 lay 9 percentage points above the measured number; the measured number falls inside the stated range.
By their numbers in this assay, from the lowest: compound 1; then compounds 4 and 3 (each within the scatter of the next); then compound 2.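

In this assay, fluoro in place of methyl on an aromatic carbon of the core gives a number 6 percentage points lower from compound 3 to compound 4 (within the scatter), so with 3,5-dichlorophenyl on the sulfonyl sulfur this read-out does not separate the two groups at this position. On the shared fluoro core the sulfonyl substituent counts for more: 3,5-dichlorophenyl in place of phenyl gives a number 29 percentage points higher from compound 1 to compound 4 (beyond the scatter), while 3,5-dichlorophenyl in place of 4-fluorophenyl gives a number 18 percentage points lower from compound 2 to compound 4 (beyond the scatter), placing the dichlorinated group between the other two. No measurement at hand speaks to the origin of these steps.

As far as these compounds go, whether methyl and fluoro also read alike with 4-fluorophenyl or phenyl on the sulfur remains open. So does the effect of a methoxy, a nitrile or an amine on the same aromatic carbon, and a read-out at one concentration gives no potency for any of these compounds.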